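Swapping the amide aryl group in a series at the limit

The source may report more compounds than this note shows. Statements on the series, on what has been measured and on what is new or still open speak of the compounds shown alone.

Compound 1, `O=C(Nc1ccc(Sc2nc3ccccc3s2)c(Cl)c1)c1cc(Br)cc(Br)c1`, gives only the assay limit > 100000 nM in an assay on isolated protein for inhibition of thiosulfate sulfurtransferase (Homo sapiens), with a stated time of 60 min, in the absence of a further agent; on this read-out higher numbers stand for weaker inhibition and lower numbers for stronger inhibition. Compound 2, `COc1ccc(Br)cc1C(=O)Nc1ccc(Sc2nc3ccccc3s2)cc1`, likewise gives only the limit > 100000 nM in this assay. Compound 3, `O=C(Nc1ccc(Sc2nc3ccccc3s2)cc1)c1cc(Br)cc(Br)c1`, also gives only the limit > 100000 nM in this assay.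

Compound 3 therefore stands at the limit, where all three values sit (the limit of > 100000 nM in this assay, at which 3 of the 3 values shown sit). Because of this, the steps a step that the two limits leave unreadable from compound 1 to compound 3 and a step that the two limits leave unreadable from compound 2 to compound 3 cannot be read. Compound 4, `COc1ccccc1C(=O)Nc1ccc(Sc2nc3ccccc3s2)cc1`, differs from compound 3 by 2-methoxyphenyl in place of 3,5-dibromophenyl on a carbonyl carbon. Compound 2 already carries a methoxy group on its aryl amide and gives only the limit > 100000 nM. Compound 4 is therefore expected to remain near that limit, at 100000 nM within 30000 nM to 300000 nM. The expected step of a number no higher from compound 3 to compound 4 (the limit leaves the size open) is thus essentially none.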

Compound 4, half-maximal inhibitory concentration: > 100000 nM
Compound 4: a limit, no number; the forecaster's own chance of this, stated with the estimate: 80%; the middle value sits exactly at the limit.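

Compound 4 also gives a limit rather than a number, so its steps from compound 3 and from compound 2 cannot be read: the limit of > 100000 nM in this assay, at which 4 of the 4 values shown sit.

The compounds shown leave open which change to the shared core, if any, would give a measurable value in this assay.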